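The source may report more compounds than this note shows. Statements on the series, on what has been measured and on what is new or still open speak of the compounds shown alone.

Three compounds share one core and were tested in a functional assay on OVCAR-3 cells (Homo sapiens) for inhibition, read by sulforhodamine B assay, with a stated time of 48 h; on this read-out higher numbers stand for weaker inhibition of growth and lower numbers for stronger inhibition of growth. Compound 3 `Cc1cc(O)cc(-c2nn(CC#N)cc2-c2ccnc(-c3ccc(Oc4ccccc4)cc3)c2)c1` gives 3950 nM there. Compound 2 `COc1cc(C)cc(-c2nn(CC#N)cc2-c2ccc(-c3cccc(C(C)=O)c3)nc2)c1` gives 3300 nM in this assay, a number within the usual scatter of that of compound 3, so the two cannot be ranked. Compound 1 `COc1cc(C)cc(-c2c(-c3ccnc(-c4ccc(C(C)=O)cc4)c3)cnn2CC#N)c1` gives 8050 nM in this assay, a higher number that lies beyond the scatter from compound 3. The untested compound 4 `Cc1cc(O)cc(-c2nn(CC#N)cc2-c2ccnc(-c3ccc(N(C)C)cc3)c2)c1` differs from compound 3 in one place: dimethylamino in place of phenoxy on an aromatic carbon. Among the compounds with values here, no pair of measured compounds shows this exchange, so nothing here tells its size; the expectation is a step from compound 3 to compound 4 of a 1.1-fold higher number from compound 3 to compound 4 (0.06 log units; within the scatter), likely none beyond the scatter. Compound 4 is therefore estimated at 4500 nM in this assay, within 1500 nM to 13000 nM.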

Compound 4, concentration for total growth inhibition: 4780 nM
Compound 4: the middle estimate sits 1.1-fold (0.03 log units) below what was measured; the range from low to high includes it.
By their numbers in this assay, from the lowest: compounds 2, 3, 4 and 1 (each within the scatter of the next, the first and the last beyond it).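

Within the data shown here, the exchange of phenoxy for dimethylamino in this assay gives a 1.2-fold higher number from compound 3 to compound 4 (0.08 log units; within the scatter) and is the first comparison here between compounds that differ in one place. On this aromatic carbon, para to a large group, a group with a ring and one without give numbers that cannot be told apart. Nothing available explains why this step stays so small. Going by these compounds, a primary amine or a carboxylic acid at this place remains open, as does whether the same exchange would stay within the scatter on the other compounds.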